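Halogen swap on a hydrazone: tolerability on Vero cells

The compounds below may be only part of what the source reports. "The series", "measured", "known", "first", "only" and "open" are said of these compounds alone.

In an ADME assay on Vero cells (Chlorocebus sabaeus) for cytotoxicity, read by microscopy (a higher number here means that more compound is tolerated, a lower number that less compound is tolerated), compound 1 `O=C(N/N=C/c1cccc(Cl)c1)c1cccnc1` gives > 100 ug/mL, which is a limit of the assay rather than a number.
Compound 2 `O=C(N/N=C/c1ccc(Cl)cc1)c1cccnc1` gives > 100 ug/mL, again only a limit.
Compound 3 `O=C(N/N=C/c1cccc(Br)c1)c1cccnc1` gives >= 100 ug/mL, also a limit.

Compound 4 `O=C(N/N=C/c1ccc(Br)cc1)c1cccnc1` has not yet been measured. The cores of compound 1 and compound 2 hold the same atoms joined differently; the difference between the two cores is not broken down here. From compound 1 to compound 3 the change is bromo in place of chloro on an aromatic carbon, and the step that the two limits leave unreadable from compound 1 to compound 3: with both values sitting at limits, as the limit of > 100 ug/mL in this assay, at which 2 of the 3 values shown sit, and the limit of >= 100 ug/mL in this assay, at which 1 of the 3 values shown sits, record, its size cannot be read. From compound 2 to compound 4 the change is the same kind of change, (bromo in place of chloro on an aromatic carbon), the halogen here standing para to a large group rather than meta to a large group. The expectation for compound 4 rests on the limit of > 100 ug/mL in this assay, at which 2 of the 3 values shown sit, and the limit of >= 100 ug/mL in this assay, at which 1 of the 3 values shown sits: every measured value sits at a limit. The expected step is a number no higher from compound 2 to compound 4 (the limit leaves the size open), essentially flat. Compound 4 is expected to come out at 100 ug/mL, most likely again reported only as a limit in this assay.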

Compound 4, minimum cytotoxic concentration: > 100 ug/mL
Compound 4 gave a limit, no number; the forecaster's own chance of this, stated with the estimate: 80%; the middle value lies on the limit itself.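

Compound 2 and compound 4 both give only a limit, not a number, so the size of the step from chloro to bromo between them cannot be read: the limit of > 100 ug/mL in this assay, at which 3 of the 4 values shown sit.

The compounds shown leave open what concentration of any of these four compounds would start to harm the cells in this assay, and whether chloro and bromo differ at that point.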